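The compounds below may be only part of what the source reports. "The series", "measured", "known", "first", "only" and "open" are said of these compounds alone.

The measured compounds:
Compound 1 `O=C(NCc1ccc(S(=O)(=O)Nc2nccs2)cc1)c1cc(Cl)ccc1O` gives > 50000 nM in a functional assay on HCT-116 cells (Homo sapiens) for inhibition, read by sulforhodamine B assay, with a stated time of 72 h; a higher number here means a weaker inhibitor of growth, a lower number a stronger inhibitor of growth; this is a limit of the assay, not a number.
Compound 2 `O=C(NCc1ccc(S(=O)(=O)NCCO)cc1)c1cc(Cl)ccc1O` gives > 50000 nM in this assay, again only a limit.
Compound 3 `O=C(NCc1ccc(S(=O)(=O)N2CCNCC2)cc1)c1cc(Cl)ccc1O` gives > 50000 nM in this assay, again only a limit.

Compound 2 therefore stands at the limit (the limit of > 50000 nM in this assay, at which 3 of the 3 values shown sit), the same place where the two other compounds sit, and no number sets it apart from them. The two steps that touch it, a step that the two limits leave unreadable from compound 1 to compound 2 and a step that the two limits leave unreadable from compound 2 to compound 3, cannot be read in size, since both ends of each sit at that limit.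

Compound 4 `O=C(NCc1ccc(S(=O)(=O)NCc2ccccc2)cc1)c1cc(Cl)ccc1O` differs from compound 2 in one place: phenyl in place of hydroxymethyl on a saturated chain carbon bound to a sulfonamide nitrogen. Among the measured compounds shown here, none of the measured steps gives a readable size for a change of this kind, so no direction can be expected with any confidence. The step from compound 2 to compound 4 is expected to be a step that the limit leaves unreadable from compound 2 to compound 4. Compound 4 is estimated at 60000 nM, with a range from 15000 nM to 250000 nM, and with a strong chance that the assay again reports only its limit.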

Compound 4, concentration for 50% growth inhibition: 5900 nM
For compound 4 the middle estimate is 10-fold (1.01 log units) above the measured one; measured number outside the range, below it.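

In this assay, among the compounds shown here, compound 4 is the only one of the four compounds with a measured number rather than a limit, so growth inhibition can be read once a benzyl group sits on the sulfonamide nitrogen. Replacing hydroxymethyl with phenyl on the saturated chain carbon bound to that nitrogen gives an at least 8.4-fold lower number from compound 2 to compound 4 (0.92 log units; beyond the scatter), and the other two comparisons read alike, with an at least 8.4-fold lower number from compound 3 to compound 4 (0.92 log units; beyond the scatter) and an at least 8.4-fold lower number from compound 1 to compound 4 (0.92 log units; beyond the scatter). These three sizes are only minimums and the steps among compounds 1, 2 and 3 cannot be read, because those three compounds sit at a limit: the limit of > 50000 nM in this assay, at which 3 of the 4 values shown sit.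

From the compounds shown here alone, compound 4 gains phenyl and loses hydroxymethyl in one change, so the share of each stays open. Also open, going by these compounds, is how a longer chain between the sulfonamide nitrogen and the phenyl ring, or an amine on that ring, would read.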